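Benzoyl in place of pivaloyl on a cephem sulfone scaffold

The source may hold more compounds than are shown below. What is called first, only, known or untested is meant among the compounds shown, and "the series" means these compounds.

Measured compounds:
- compound 1, `CO[C@H]1C(=O)N2C(C(=O)c3ccccc3)=C(C)[C@@H](Sc3nnnn3C)S(=O)(=O)C12`: 200 h
- compound 2, `CO[C@H]1C(=O)N2C(C(=O)C(C)(C)C)=C(CSc3nnnn3C)[C@@H](Sc3nnnn3C)S(=O)(=O)C12`: 31 h

Of the compounds shown here, two have been measured in a physicochemical assay, at pH 7.4; a higher number here means that the compound lasts longer, a lower number that the compound disappears faster. Compound 1, which carries a benzoyl group and a methyl on the shared core, gives 200 h in this assay. Compound 2, which carries a (tert-butyl)carbonyl group and a thiomethyltetrazole-bearing chain on the same core, gives 31 h. Compound 2 stands lowest of the two numbers, and the gap to compound 1 is beyond the scatter; since the two structures differ in more than one place, the two values show only where each stands and not what either change alone does.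

Compound 3, `CO[C@H]1C(=O)N2C(C(=O)c3ccccc3)=C(CSc3nnnn3C)[C@@H](Sc3nnnn3C)S(=O)(=O)C12`, is the next compound. It keeps the thiomethyltetrazole-bearing chain of compound 2 and changes the acyl group: phenyl in place of tert-butyl on a carbonyl carbon. Among the compounds with values here, no measured pair isolates this change. Within the data shown here, the only compound with a benzoyl group, compound 1, gives 200 h, which is the higher of the two numbers, so a modest rise is expected in this assay for compound 3, with a 1.9-fold higher number from compound 2 to compound 3 (0.29 log units; within the scatter) as the expected step. Compound 3 is expected to give about 60 h in this assay, within a range from 25 h to 150 h.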

Compound 3, half-life: 1400 h
The estimate for compound 3 lay 23-fold (1.37 log units) below the measured number; the measured number lies above the stated range.
By their numbers in this assay, from the lowest: compound 2; then compound 1; then compound 3.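

In this assay, within the data shown here, the change from tert-butyl to phenyl on a carbonyl carbon, with everything else held the same, gives a 45-fold higher number from compound 2 to compound 3 (1.65 log units; beyond the scatter) and so provides the first direct reading of this position, where the step is large. The other single change, (1-methyl-1H-tetrazol-5-yl)sulfanyl in place of hydrogen on a saturated chain carbon bound to a double-bonded ring carbon, gives a 7.0-fold higher number from compound 1 to compound 3 (0.85 log units; beyond the scatter) with the benzoyl group kept, so the lower number of compound 2 cannot be read as a plain effect of that chain, as this step also runs upward. Nothing at hand explains why either change moves the half-life as it does.

What the change from tert-butyl to phenyl does on the core of compound 1, which carries a methyl in place of the chain, stays open, as only the benzoyl group appears with that methyl among these compounds. Also open, as far as these compounds go, is how a cyclohexyl ring on the same carbonyl carbon, or a phenyl bearing a methoxy group, would compare with the phenyl of compound 3.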